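A few compounds are considered here, and "the series" means these few. Any claim that something is new, unique, unknown or untested is made for them only; others in the source may bear on it.

Working notes on the series in a functional assay on U2OS cells (Homo sapiens) for cytotoxicity, read by MTT assay, with a stated time of 48 h; a lower number here means a stronger inhibitor, a higher number a weaker inhibitor.

Compound 1 `Fc1cccc(-c2nc(Nc3cccc(Cl)c3)c3cc(F)ccc3n2)c1` gives in this assay only a limit, > 50000 nM, so no number is attached to it. Among the compounds with values here, compound 2 `Nc1ccc(Nc2nc(-c3cccc(F)c3)nc3ccc(F)cc23)cc1` is the only member with a number, giving 44200 nM in this assay. Within the data shown here, the one measured step, an at least 1.1-fold lower number from compound 1 to compound 2 (0.05 log units; that floor lies within the scatter), is anchored on a limit of > 50000 nM in this assay, at which 1 of the 2 values shown sits, and shows no change beyond the scatter.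

Compound 3 `Nc1ccccc1Nc1nc(-c2cccc(F)c2)nc2ccc(F)cc12` differs from compound 2 by 2-aminophenyl in place of 4-aminophenyl on a nitrogen on an aromatic ring. This is a move of the amino group within the same ring, with nothing added or removed. Among the measured compounds shown here, the step from compound 1 to compound 2, which swapped a 3-chlorophenyl for a 4-aminophenyl at the same nitrogen, produced no shift beyond the scatter, and no other step is available to weigh a positional move of the amino group. On that basis no step beyond the scatter is expected in this assay, and compound 3 is expected to stay in the same weak region as compound 2, with the change estimated as a 1.0-fold higher number from compound 2 to compound 3 (0.01 log units; within the scatter). Compound 3 is therefore estimated at 45000 nM, within 15000 nM to 120000 nM, with a real chance that only a limit is reported.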

Compound 3, half-maximal inhibitory concentration: 37900 nM
The estimate for compound 3 lay 1.2-fold (0.07 log units) above the measured number; the range from low to high includes it.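

In this assay, 2-aminophenyl in place of 4-aminophenyl on the nitrogen gives a 1.2-fold lower number from compound 2 to compound 3 (0.07 log units; within the scatter), so moving the amino group around this ring produces no readable change between these two compounds. 2-aminophenyl in place of 3-chlorophenyl gives an at least 1.3-fold lower number from compound 1 to compound 3 (0.12 log units; that floor lies within the scatter), so neither aminophenyl group shown has a step from the 3-chlorophenyl compound beyond the scatter. Compound 1 gives only a limit, > 50000 nM, so this step is a floor and its true size cannot be read: the limit of > 50000 nM in this assay, at which 1 of the 3 values shown sits.

The compounds shown leave open whether 3-aminophenyl, or a carboxylic acid or a longer chain carrying an amine on this ring, would shift the number in this assay beyond the scatter. They also leave open whether a change elsewhere on the shared core, such as replacing the 3-fluorophenyl group that all three compounds carry, would move the series out of this weak region.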